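Methoxy to methyl on the aryl ring: working notes

A few compounds are considered here, and "the series" means these few. Any claim that something is new, unique, unknown or untested is made for them only; others in the source may bear on it.

Measured in a physicochemical assay for solubility, measured as kinetic solubility; a higher number here means a more soluble compound, a lower number a less soluble compound:
compound 1 `CCC/N=C1\S/C(=C\c2ccc(O)cn2)C(=O)N1c1ccccc1C`: 110000 nM
compound 2 `CCC/N=C1\S/C(=C\c2ccc(O)cc2)C(=O)N1c1ccccc1C`: 79000 nM
compound 3 `CCC/N=C1\S/C(=C\c2ccc(O)c(Cl)c2)C(=O)N1c1ccccc1OC`: 79000 nM
Not yet measured: compound 4 `CCC/N=C1\S/C(=C\c2ccc(O)c(Cl)c2)C(=O)N1c1ccccc1C`

Compound 3 stands level with compound 2 at the digits shown and within the scatter of compound 1. The change to compound 4 is methyl in place of methoxy on an aromatic carbon, ortho to a large group: methyl in place of methoxy on an aromatic carbon. Among the compounds with values here, no measured step covers this change. Within the data shown here, the only step available, a 1.4-fold lower number from compound 1 to compound 2 (0.14 log units; within the scatter), concerns a different group, 4-hydroxyphenyl in place of 5-hydroxypyridin-2-yl. All three values lie within the scatter of each other, so no shift beyond the scatter is expected in this assay. The expected step is a 1.3-fold lower number from compound 3 to compound 4 (0.12 log units; within the scatter). Compound 4 is estimated at 60000 nM, with an expected range from 25000 nM to 110000 nM.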

Compound 4, solubility: 79000 nM
Compound 4: middle estimate off by 1.3-fold (0.12 log units), on the low side, and the stated range covers the measured number.
By their numbers in this assay, from the lowest: compounds 2, 3, 4 and 1 (each within the scatter of the next).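

In this assay, methyl in place of methoxy on this aromatic carbon now has a measured step, no change at the digits printed from compound 3 to compound 4 (within the scatter), so the 2-methoxyphenyl to 2-methylphenyl change stays within the scatter. Chloro in place of hydrogen gives no change at the digits printed from compound 2 to compound 4 (within the scatter), and 3-chloro-4-hydroxyphenyl in place of 5-hydroxypyridin-2-yl gives a 1.4-fold lower number from compound 1 to compound 4 (0.14 log units; within the scatter), both also within the scatter. No supporting data bear on these results.

Still open, from the compounds shown here alone, is how an amine or a carboxylic acid on this aromatic carbon would read in this assay, and whether any group there gives a step beyond the scatter.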